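Swapping Ring Nitrogens on a Thiophene Allosteric Modulator

The compounds below may be only part of what the source reports. "The series", "measured", "known", "first", "only" and "open" are said of these compounds alone.

Of the compounds shown here, two of one shared core have been measured so far. Compound 1 `Nc1sc(-c2ccccc2)cc1C(=O)c1ccc(Cl)cc1` carries a phenyl group, and in an assay on CHO cells for positive allosteric modulation of adenosine receptor A1 (Homo sapiens), read by ERK phosphorylation, tested at 3 uM (on this read-out higher numbers stand for a weaker effect at the one concentration tested and lower numbers for a stronger effect), compound 1 gives 46%. Compound 2 `Nc1sc(-c2cncnc2)cc1C(=O)c1ccc(Cl)cc1` carries a pyrimidin-5-yl group in the same place, and in this assay compound 2 gives 7%. Going by the values given here, the single step between them, a number 39 percentage points lower from compound 1 to compound 2 (beyond the scatter), is the only one available, and it leaves compound 2 standing at the lowest of the two numbers, meaning the stronger effect of the pair.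

Compound 3 `Nc1sc(-c2ccncc2)cc1C(=O)c1ccc(Cl)cc1` is not yet measured. It differs from compound 2 in one place: pyridin-4-yl in place of pyrimidin-5-yl on an aromatic carbon. The new group is, in its count of ring nitrogens, between the pyrimidin-5-yl of compound 2 and the phenyl of compound 1. Among the compounds with values here, the one relevant step, a number 39 percentage points lower from compound 1 to compound 2 (beyond the scatter), was large. Compound 3 is therefore expected in this assay to come out somewhere between its two neighbours, with the expected step of a number 15 percentage points higher from compound 2 to compound 3 (beyond the scatter) pointing upward but smaller than the measured one. The estimate for compound 3 is 22%, within a range from 5% to 45%.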

Compound 3, a percentage reported as activity, at one concentration (the size of the read-out at that concentration, not a potency): 44%
Compound 3: middle estimate off by 22 percentage points, on the low side; the range from low to high includes it.
By their numbers in this assay, from the lowest: compound 2; then compounds 3 and 1 (each within the scatter of the next).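

On the carbon next to the ring sulfur, the result separates two things that compound 2 alone could not: having a nitrogen-containing ring there and having the pyrimidin-5-yl group in particular. In this assay, the step is a number 2 percentage points lower from compound 1 to compound 3 (within the scatter), so replacing phenyl with pyridin-4-yl, a ring with 1 hetero atom, gives no change that can be told from scatter. The step in the other direction is a number 37 percentage points higher from compound 2 to compound 3 (beyond the scatter), which means that among these three compounds the read-out does not change gradually with the count of ring nitrogens: compound 2 stands apart, while compound 3 and compound 1 cannot be told apart.

Still open, on these data alone, is whether the count of ring nitrogens or their place in the ring decides the outcome, a question that a pyridin-3-yl or pyrimidin-2-yl group on the same carbon of the shared core could help to settle. Nothing at hand gives a measured reason for the difference between pyrimidin-5-yl and pyridin-4-yl.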